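The source may report more compounds than this note shows. Statements on the series, on what has been measured and on what is new or still open speak of the compounds shown alone.

Measured in a functional assay on DLD-1 cells (Homo sapiens) for cytotoxicity, with a stated time of 48 h; a higher number here means a weaker inhibitor, a lower number a stronger inhibitor:
Compound 1 `CCCC(=O)Oc1ccc2oc(/C=C/[S+](C)[O-])cc(=O)c2c1`: 8700 nM
Compound 2 `Cc1c(/C=C/[S+](C)[O-])oc2ccccc2c1=O`: 7200 nM
Compound 3 `COc1cccc2oc(/C=C/[S+](C)[O-])cc(=O)c12`: > 10000 nM

In this assay compound 1 gives 8700 nM, within the scatter of compound 2 at 7200 nM. For compound 3 the result > 10000 nM is a limit of the assay, not a number.

Compound 4 `C[S+]([O-])/C=C/c1cc(=O)c2cc(C#N)ccc2o1` has not yet been measured. It carries cyano in place of (propylcarbonyl)oxy on an aromatic carbon of the core of compound 1 (cyano in place of (propylcarbonyl)oxy on an aromatic carbon). Within the data shown here, no measured pair differs in one place, so the size of this step cannot be read from the data. With compound 1 at 8700 nM and compound 2 at 7200 nM, no change beyond the scatter is expected in this assay. The expected change is a 1.3-fold lower number from compound 1 to compound 4 (0.13 log units; within the scatter). Compound 4 is estimated at 6500 nM, with an expected range from 2800 nM to 10000 nM.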

Compound 4, half-maximal inhibitory concentration: > 10000 nM
Compound 4 gave a limit, no number (the forecaster's own chance of this, stated with the estimate: 20%); middle value at least 1.5-fold (0.18 log units) away from the limit.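

In this assay, among these compounds, cyano in place of (propylcarbonyl)oxy on this aromatic carbon gives the one step on the core of compound 1 that can be read: an at least 1.1-fold higher number from compound 1 to compound 4 (0.06 log units; that floor lies within the scatter). From the compounds shown here alone, the result for compound 4 is a limit of the assay, so this step is only a floor, and its true size stays unknown because the read-out ends there: the limit of > 10000 nM in this assay, at which 2 of the 4 values shown sit. Cyano therefore gives no lower number than (propylcarbonyl)oxy here, but whether it raises the number beyond the scatter cannot be told.

Going by these compounds, it remains open whether an amine, a hydroxyl or a longer ester chain on this carbon would give a number within the range of the assay.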